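Acetyl in place of hydroxyl hydrogen on the shared core

This account rests on a few compounds, and the source may have more. Where it says the series, first, only, none or still open, it means among the compounds named here.

Measured so far:
compound 1, `CC(=O)OC(C)n1cnc2c(Cl)nc(I)nc21`: 6420 nM
compound 2, `CC(O)n1cnc2c(N)nc(I)nc21`: > 500000 nM

In a functional assay on HT-29 cells (Homo sapiens) for inhibition (a lower number here means a stronger inhibitor, a higher number a weaker inhibitor), compound 1 gives 6420 nM. Compound 2 sits at the limit of > 500000 nM in this assay, at which 1 of the 2 values shown sits, which is a limit of the assay and not a number; compound 2 is therefore no better placed than the weakest end of what the assay reports. The two compounds differ in more than one place, so their values are set side by side without a step being drawn between them.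

Compound 3, `CC(=O)OC(C)n1cnc2c(N)nc(I)nc21`, is the next member to be measured. It differs from compound 2 by acetyl in place of hydrogen on an oxygen on a saturated carbon. Among the measured compounds shown here, no measured pair shows this change alone, so the size of its step is open. In this assay compound 3 is expected at 60000 nM, with a range from 6000 nM to 500000 nM. The step of an at least 8.3-fold lower number from compound 2 to compound 3 (0.92 log units; beyond the scatter) is the expected gain, worded only as an estimate, and a further limit reading remains a real possibility.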

Compound 3, half-maximal inhibitory concentration: > 500000 nM
Compound 3 gave a limit, no number (the forecaster's own chance of this, stated with the estimate: 40%); at least 8.3-fold (0.92 log units) between middle value and limit.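

In this assay, the change from hydroxy to acetoxy on the saturated carbon brings no readable shift, and the step between compound 2 and compound 3 cannot be read, since both values are limits: the limit of > 500000 nM in this assay, at which 2 of the 3 values shown sit. Among the compounds shown here, with acetoxy kept in place, amino in place of chloro on an aromatic carbon gives an at least 77-fold higher number from compound 1 to compound 3 (1.89 log units; beyond the scatter) and so marks the aromatic position as the only place where a change can be sized so far. The value of compound 3 at the far end of that step is a limit and not a number.

From the compounds shown here alone, it remains open how hydroxy in place of acetoxy reads when chloro is kept on the shared core. Also open, going by these compounds, is whether methoxy in place of chloro, or propanoyl in place of acetyl, would give a number rather than a limit.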